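Removing the Ring Bromine: Expected Effect on Antiproliferative Potency

A few compounds are considered here, and "the series" means these few. Any claim that something is new, unique, unknown or untested is made for them only; others in the source may bear on it.

Three measured compounds share one core and differ only in the halogen-bearing phenyl group attached to the double-bonded chain. In a functional assay on PC-3 cells (Homo sapiens) for antiproliferative activity, read by MTT assay, with a stated time of 72 h (on this read-out lower numbers stand for stronger inhibition and higher numbers for weaker inhibition), compound 1 `O=C(COc1ccc(C(=O)/C=C/c2ccccc2Cl)cc1)N[C@H]1CCOC1=O` gives 4610 nM, compound 2 `O=C(COc1ccc(C(=O)/C=C/c2ccc(F)cc2)cc1)N[C@H]1CCOC1=O` gives 15600 nM, and compound 3 `O=C(COc1ccc(C(=O)/C=C/c2cccc(Br)c2)cc1)N[C@H]1CCOC1=O` gives 7890 nM. The number for compound 3 is the second highest of the three, though its gaps to compound 1 and compound 2 both lie within the scatter. Compound 4 `O=C(COc1ccc(C(=O)/C=C/c2ccccc2)cc1)N[C@H]1CCOC1=O` carries hydrogen in place of bromo on an aromatic carbon. Within the data shown here, no measured step removes a halogen outright; the nearest guides are a 3.4-fold higher number from compound 1 to compound 2 (0.53 log units; beyond the scatter), which was modest, and a 1.7-fold higher number from compound 1 to compound 3 (0.23 log units; within the scatter) and a 2.0-fold lower number from compound 2 to compound 3 (0.30 log units; within the scatter), both within the scatter. A small step toward a higher number, a 1.4-fold higher number from compound 3 to compound 4 (0.14 log units; within the scatter), is therefore expected in this assay. Compound 4 is estimated at 11000 nM, ranging from 4500 nM to 27000 nM.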

Compound 4, half-maximal inhibitory concentration: 56800 nM
The estimate for compound 4 lay 5.2-fold (0.71 log units) below the measured number; the whole stated range lies below it.
By their numbers in this assay, from the lowest: compounds 1, 3 and 2 (each within the scatter of the next, the first and the last beyond it); then compound 4.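

In this assay a halogen on this phenyl ring proves to matter: compound 4, with none, has the highest number and is the weakest of the four. Replacing bromo with hydrogen gives a 7.2-fold higher number from compound 3 to compound 4 (0.86 log units; beyond the scatter) while replacing fluoro gives a 3.6-fold higher number from compound 2 to compound 4 (0.56 log units; beyond the scatter) and replacing chloro gives a 12-fold higher number from compound 1 to compound 4 (1.09 log units; beyond the scatter) so each loss of a halogen lies beyond the scatter. Nothing available explains this loss of potency. Going by these compounds, whether a methyl or methoxy group on this ring could restore the potency seen with the halogens remains open.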